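The compounds below may be only part of what the source reports. "The series", "measured", "known", "first", "only" and "open" are said of these compounds alone.

Among the compounds with values here, in a functional assay on the whole organism (strain Kunming) with Mus musculus as the target, with a stated time of 0.5 h (a lower number here means that less compound is needed, a higher number that more compound is needed for the effect), compound 2 `COc1cc(OC)c(OC)cc1/C=C/COC(=O)/C=C/c1ccccc1Cl` gives 639 umol/kg, the only true number available so far. Compound 1 `COc1cc(OC)c(OC)cc1/C=C/COC(=O)/C=C/c1ccc(Br)cc1` gives only a limit, > 692 umol/kg. The next analogue, compound 3 `COc1cc(OC)c(OC)cc1/C=C/COC(=O)/C=C/c1ccc(F)cc1`, keeps the shared core and the ester chain but carries 4-fluorophenyl in place of 2-chlorophenyl on a double-bonded chain carbon bound to a double-bonded chain carbon. Within the data shown here, one measured step bears on this change, since it alters the same aromatic group: 2-chlorophenyl in place of 4-bromophenyl gives an at least 1.0-fold lower number from compound 1 to compound 2 (0.03 log units; that floor lies within the scatter). As far as these compounds go, that figure is only a floor, so the true size of the step remains unknown, and this single pair cannot establish a trend. Among the measured compounds shown here, with that step of compound 2 as the only guide, no change beyond the scatter is expected in this assay, and neither direction is favoured. The expected step is a 1.0-fold higher number from compound 2 to compound 3 (0.01 log units; within the scatter). For compound 3, the estimated value is 650 umol/kg, with an expected range of 350 umol/kg to 1200 umol/kg.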

Compound 3, dose for half-maximal effect: > 805 umol/kg
Compound 3: no number, only a limit (the forecaster's own chance of this, stated with the estimate: 45%); middle value at least 1.2-fold (0.09 log units) from the limit.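

In this assay, exchanging the aromatic group gives an at least 1.2-fold higher number from compound 2 to compound 3 (0.10 log units; that floor lies within the scatter). That figure is only a floor and lies within the scatter, so this change cannot yet be called a real loss or be given a true size. Within the data shown here, compound 3 gives a limit of the assay rather than a number, and compound 1 shares that outcome, which leaves compound 2 as the only compound of the three with a true number and makes the step between the two limits, fluoro in place of bromo on an aromatic carbon, unreadable.

The compounds shown leave open how far the true doses of compound 1 and compound 3 lie from the limits reached, and so whether swapping one halogen-bearing phenyl group for another matters at all at this place. They also leave open whether a phenyl group carrying something other than a halogen, such as a dimethylamino group or a carboxylic acid, would shift the number clearly in either direction.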